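The source may hold more compounds than are shown below. What is called first, only, known or untested is meant among the compounds shown, and "the series" means these compounds.

Compound 1 `CCCCc1nc(C)c(CCC(=O)OCC)c(=O)n1Cc1ccc(-c2ccccc2-c2nnn[nH]2)cc1`: 0.066 mg/kg
Compound 2 `CCCCc1nc(C)c(CCC(=O)N2CCSCC2)c(=O)n1Cc1ccc(-c2ccccc2-c2nnn[nH]2)cc1`: 0.204 mg/kg

Going by the values given here, in an in vivo functional assay on the whole organism for inhibition, with Rattus norvegicus as the target (on this read-out higher numbers stand for an effect only at larger amounts of compound and lower numbers for an effect already at smaller amounts), compound 2 gives 0.204 mg/kg, the higher of the two numbers so far. Compound 3 `CCCCc1nc(C)c(CC(=S)N(CC)CC)c(=O)n1Cc1ccc(-c2ccccc2-c2nnn[nH]2)cc1` is still unmeasured and differs from compound 2 as follows: a group of 7 heavy atoms (5 carbon, 1 nitrogen, 1 sulfur; no ring) in place of a group of 9 heavy atoms (6 carbon, 1 nitrogen, 1 oxygen, 1 sulfur; one six-membered non-aromatic ring with 2 hetero atoms), on a saturated chain carbon bound to an aromatic carbon. Among the compounds with values here, only one measured step bears on this change, and only loosely: a 3.1-fold higher number from compound 1 to compound 2 (0.49 log units; beyond the scatter), a modest step in which thiomorpholin-4-yl replaced ethoxy on a carbonyl carbon. It shows no direction for the new group, so no shift beyond the scatter is expected in this assay. The expected step is a 1.0-fold lower number from compound 2 to compound 3 (0.01 log units; within the scatter). The estimate for compound 3 is 0.2 mg/kg, with a wide range from 0.05 mg/kg to 0.8 mg/kg.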

Compound 3, dose for half-maximal effect: 0.023 mg/kg
Beside the measured number, compound 3's estimate is 8.7-fold (0.94 log units) above it, outside the stated range (below it).
By their numbers in this assay, from the lowest: compound 3; then compound 1; then compound 2.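

In this assay, the group on the saturated chain carbon bound to an aromatic carbon clearly matters: the ring-free, sulfur-bearing group of compound 3 gives an 8.9-fold lower number from compound 2 to compound 3 (0.95 log units; beyond the scatter), and against the ester gives a 2.9-fold lower number from compound 1 to compound 3 (0.46 log units; beyond the scatter). It therefore acts at smaller amounts than either earlier group, so this position can gain as well as lose. No measurement here accounts for that gain. As far as these compounds go, whether it belongs to the sulfur, the ethyl groups on nitrogen or the chain length stays open, as does the behaviour of a version with carbonyl oxygen in place of sulfur, or with a morpholine ring in place of the ethyl groups.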